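The source may hold more compounds than are shown below. What is called first, only, known or untested is meant among the compounds shown, and "the series" means these compounds.

Measured in a functional assay on HeLa cells (Homo sapiens) for cytotoxicity, read by MTT assay, with a stated time of 120 h; on this read-out higher numbers stand for weaker inhibition and lower numbers for stronger inhibition:
Compound 1 `COc1ccc2oc(=O)sc2c1C(=O)/C=C/c1ccc([N+](=O)[O-])cc1`: "not determined" (no result reported)
Compound 2 `COc1ccc2oc(=O)sc2c1C(=O)/C=C/c1ccc(N(C)C)cc1`: > 100000 nM

For the measured compounds named here, compound 1 has no result, so compound 2 provides the only reading for this series. Compound 2 gives > 100000 nM, which is a limit of the assay and not a number. Going by the values given here, the data therefore hold only (the limit of > 100000 nM in this assay, at which 1 of the 2 values shown sits), and no measured step is available for comparison.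

Compound 3 `COc1ccc2oc(=O)sc2c1C(=O)/C=C/c1ccc(Cl)cc1` shares the core of compound 2 but has chloro in place of dimethylamino on an aromatic carbon, para to a large group (chloro in place of dimethylamino on an aromatic carbon). Among the compounds with values here, with no measured step as a guide, any forecast for this assay is rough. The only direction open to a numerical result is toward stronger inhibition, and a moderate step seems more likely than a very large one. Compound 3 could also end up reported only as a limit. The estimated change is an at least 4.0-fold lower number from compound 2 to compound 3 (0.60 log units; beyond the scatter). For compound 3 the expected value is 25000 nM, with an estimated range of 5000 nM to 100000 nM.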

Compound 3, half-maximal inhibitory concentration: 5200 nM
Compound 3: middle estimate off by 4.8-fold (0.68 log units), on the high side, and the stated range covers the measured number.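

In this assay, the aromatic carbon para to a large group now proves sensitive to what it carries, which a single limit could not show. Chloro in place of dimethylamino gives an at least 19-fold lower number from compound 2 to compound 3 (1.28 log units; beyond the scatter), a large change that turns a reading with no exact number into a measured one. This single change removes a group of 3 heavy atoms and puts 1 chlorine atom in its place, with the rest of the molecule untouched. As far as these compounds go, the true size of the step stays unknown because compound 2 sits at a limit of the assay and not at a number: the limit of > 100000 nM in this assay, at which 1 of the 3 values shown sits.

With only one measured step, the compounds shown cannot separate what chloro itself contributes from what follows from the loss of dimethylamino. Compounds carrying bromo, methoxy or a plain hydrogen at this same place would show whether the reading depends on chloro in particular or whether many groups other than dimethylamino give a similar number.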